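A few compounds are considered here, and "the series" means these few. Any claim that something is new, unique, unknown or untested is made for them only; others in the source may bear on it.

In a functional assay on BHK-21 cells (Mesocricetus auratus) for cytotoxicity, read by MTT assay (on this read-out higher numbers stand for lower toxicity in this test and lower numbers for higher toxicity in this test), compound 1 `O=C(c1ccccc1)N1N=C(c2cccs2)CC1c1ccc(Br)cc1` gives > 300000 nM, which is a limit. Compound 2 `COc1ccc(C2CC(c3cccs3)=NN2C(=O)c2ccccc2)cc1` gives > 300000 nM, also a limit. Compound 3 `O=C(c1ccccc1)N1N=C(c2ccc(Br)s2)CC1c1ccc(Cl)cc1` gives > 300000 nM, likewise a limit and not a number. Among the compounds with values here, the series so far stands at the limit of > 300000 nM in this assay, at which 3 of the 3 values shown sit.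

Compound 4 `CC(C)(C)C1=NN(C(=O)c2ccccc2)C(c2ccc(Cl)cc2)C1` carries tert-butyl in place of 5-bromothiophen-2-yl on a carbon with a double bond to nitrogen.

Within the data shown here, the only measured step is a step that the two limits leave unreadable from compound 1 to compound 2, a different exchange that gives no size to carry over. No step beyond the scatter is therefore expected in this assay, and no direction can be expected. The estimated change is a number no higher from compound 3 to compound 4 (the limit leaves the size open). Compound 4 is expected near 300000 nM, with an estimated range of 100000 nM to 600000 nM.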

Compound 4, half-maximal cytotoxic concentration: 65000 nM
Estimate against measurement, compound 4: 4.6-fold (0.66 log units) above; the measured number lies below the stated range.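

In this assay, the carbon with a double bond to nitrogen proves to be a position that can move the read-out: tert-butyl in place of 5-bromothiophen-2-yl gives an at least 4.6-fold lower number from compound 3 to compound 4 (0.66 log units; beyond the scatter). Within the data shown here, this is the first readable step, and it points to higher toxicity in this test. The other compounds give no number, only a limit: the limit of > 300000 nM in this assay, at which 3 of the 4 values shown sit.

One exchange cannot separate the loss of the aromatic ring from the entry of tert-butyl. Going by these compounds, whether a cyclohexyl or a phenyl at this position would keep the number down remains open.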